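Bromo in place of hydrogen: cytotoxicity notes on compounds 2 and 3

The source may hold more compounds than are shown below. What is called first, only, known or untested is meant among the compounds shown, and "the series" means these compounds.

Compound 1 `O=C(/C=C/c1ccc(N2CCCCC2)cc1)c1ccsc1` is reported in an ADME assay on PBMC cells (Homo sapiens) for cytotoxicity, with a stated time of 5 days (on this read-out higher numbers stand for weaker inhibition and lower numbers for stronger inhibition), only as a limit, > 100000 nM. Compound 2 `c1csc(C2=NNC(c3ccc(N4CCCCC4)cc3)C2)c1` gives 20800 nM in this assay; this is the only full number shown. The other entry, that of compound 1, is a limit (the limit of > 100000 nM in this assay, at which 1 of the 2 values shown sits). Going by the values given here, no step between two measured compounds is available in this set. Compound 3 `Brc1ccsc1C1=NNC(c2ccc(N3CCCCC3)cc2)C1` differs from compound 2 by bromo in place of hydrogen on an aromatic carbon. With nothing measured to rest on, the step from compound 2 to compound 3 is expected to stay within the scatter, a 1.0-fold lower number from compound 2 to compound 3 (0.02 log units; within the scatter). Compound 3 is therefore estimated at 20000 nM, between 7000 nM and 60000 nM.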

Compound 3, half-maximal inhibitory concentration: 57000 nM
The estimate for compound 3 lay 2.9-fold (0.45 log units) below the measured number; measured number inside the range.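

Bromo in place of hydrogen, thiophen-2-yl to 3-bromothiophen-2-yl, gives a 2.7-fold higher number from compound 2 to compound 3 (0.44 log units; beyond the scatter) in this assay, so this aromatic carbon of the five-membered ring is not a silent place for substitution on this read-out. The step is modest and rests on a single pair of compounds. Nothing measured here accounts for the step.

On these data alone, whether chloro, methyl or an amine on the same carbon would move the number in the same direction stays open. So does the effect of bromo on the other ring carbons.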